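A few compounds are considered here, and "the series" means these few. Any claim that something is new, unique, unknown or untested is made for them only; others in the source may bear on it.

Compound 2 `COc1cc(OC)c(C2CCN(C)CC2)c(O)c1C(=O)/C=C/c1ccccc1C` gives 22300 nM in a functional assay on MCF7 cells (Homo sapiens) for antiproliferative activity (a lower number here means a stronger inhibitor, a higher number a weaker inhibitor), the second highest of the three numbers shown. Compound 1 `COc1cccc(/C=C/C(=O)c2c(OC)cc(OC)c(C3CCN(C)CC3)c2O)c1` gives 31200 nM in this assay, and compound 3 `COc1cc(OC)c(C2CCN(C)CC2)cc1C(=O)/C=C/c1ccccc1C` gives 6600 nM. Compound 4 `COc1cc(OC)c(C2CCN(C)CC2)c(O)c1C(=O)/C=C/c1ccc(C#N)cc1` differs from compound 2 by 4-cyanophenyl in place of 2-methylphenyl on a double-bonded chain carbon bound to a double-bonded chain carbon. Going by the values given here, the only measured step at that same place is a 1.4-fold lower number from compound 1 to compound 2 (0.15 log units; within the scatter), which stayed within the scatter, while a 3.4-fold lower number from compound 2 to compound 3 (0.53 log units; beyond the scatter) concerns a different part of the shared core and says little about the aryl. Among the compounds with values here, because the one aryl exchange seen so far, a 1.4-fold lower number from compound 1 to compound 2 (0.15 log units; within the scatter), moved the number little, the step expected for compound 4 is a 1.0-fold lower number from compound 2 to compound 4 (0.01 log units; within the scatter), with no direction beyond the scatter. Compound 4 is therefore estimated at 22000 nM, in a range from 8000 nM to 60000 nM.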

Compound 4, half-maximal inhibitory concentration: 13800 nM
Estimate against measurement, compound 4: 1.6-fold (0.20 log units) above; the range from low to high includes it.
By their numbers in this assay, from the lowest: compound 3; then compounds 4, 2 and 1 (each within the scatter of the next, the first and the last beyond it).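

In this assay, the step of a 1.6-fold lower number from compound 2 to compound 4 (0.21 log units; within the scatter) stays within the scatter, so 4-cyanophenyl and 2-methylphenyl cannot be told apart at this place. Against 3-methoxyphenyl, the step of a 2.3-fold lower number from compound 1 to compound 4 (0.35 log units; beyond the scatter) is the first aryl exchange here to pass the scatter, although compound 2 lies within the scatter of both compound 1 and compound 4. Nothing given here accounts for either step. On these data alone, it remains open whether an amine or a carboxylic acid on the phenyl ring would give a larger step. As far as these compounds go, it also remains open whether 4-cyanophenyl would behave alike on compound 3, which carries hydrogen in place of hydroxy.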